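This account rests on a few compounds, and the source may have more. Where it says the series, first, only, none or still open, it means among the compounds named here.

Measured so far:
- compound 1, `COc1ccc(N(CC(=O)NCCC[Te]c2ccccc2)C(=O)c2ccccc2)cc1`, with 5000 nM in a functional assay on A-431 cells (Homo sapiens) for cytotoxicity, read by MTT assay, with a stated time of 24 h; a higher number here means a weaker inhibitor, a lower number a stronger inhibitor
- compound 2, `O=C(COC(=O)C#Cc1ccccc1)NCCC[Te]c1ccccc1`, with 7000 nM in this assay

Compound 2 gives the higher of the two numbers, but its gap to compound 1 is within the usual scatter of repeated measurements, so the two cannot be told apart on these data. Compound 3, `O=C(COC(=O)/C=C/c1ccccc1)NCCC[Te]c1ccccc1`, has not yet been measured. It differs from compound 2 in one place: 2-phenylethenyl in place of 2-phenylethynyl on a carbonyl carbon. The triple bond is thus replaced by a double bond, with the same eight carbon atoms and the same phenyl ring kept in place. Going by the values given here, no measured pair shows what such a change does here, so the expectation rests on the similarity of the two groups alone. The step from compound 2 to compound 3 is expected to be small, a 1.2-fold lower number from compound 2 to compound 3 (0.07 log units; within the scatter), with no clear direction beyond the scatter. Compound 3 is therefore estimated at 6000 nM, within a range from 2500 nM to 15000 nM.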

Compound 3, half-maximal inhibitory concentration in the A-431 assay: 6000 nM
Beside the measured number, compound 3's estimate shows no gap at the digits printed, and the stated range covers the measured number.
By their numbers in the A-431 assay, from the lowest: compounds 1, 3 and 2 (each within the scatter of the next).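

In the A-431 assay, 2-phenylethenyl in place of 2-phenylethynyl on this carbonyl carbon gives a 1.2-fold lower number from compound 2 to compound 3 (0.07 log units; within the scatter), so swapping the triple bond for a double bond produces no readable shift in this cell test. In a physicochemical assay for lipophilicity, read by HPLC, measured as octanol-water partition (a higher number here means a more lipophilic compound, a lower number a more polar compound), compound 2 gives 0.9, while compound 3 gives 3.01. The change therefore makes the compound far more lipophilic, yet the number in the A-431 assay remains within the scatter, a separation between the two read-outs that the earlier compounds could not show: the measured partition coefficient of compound 2, 0.9, and of compound 3, 3.01, a number 2.11 log units higher (beyond the scatter)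

As far as these compounds go, it remains open whether a fully saturated 2-phenylethyl group at this carbonyl carbon would also leave the cell result unmoved. Equally open, from the compounds shown here alone, is what a nitrile or an amine on the phenyl ring of compound 3 would do in either test.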